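Hydrazide in place of methylamide on the naphthyl pyridine series

This account rests on a few compounds, and the source may have more. Where it says the series, first, only, none or still open, it means among the compounds named here.

Three compounds have numbers in an assay on a protein complex for inhibition of CDK8/Cyclin C (Homo sapiens), with a stated time of 1 h; on this read-out lower numbers stand for stronger inhibition and higher numbers for weaker inhibition. Compound 1 `CCOC(=O)/C=C/c1ccncc1-c1ccc2[nH]ccc2c1` gives 107 nM. Compound 2 `CNC(=O)CCc1ccncc1-c1ccc2ccccc2c1` gives 21.1 nM, the lowest of the three numbers. Compound 3 `Cn1ccc2cc(-c3cnccc3/C=C/C(=O)N3CCOCC3)ccc21` gives 247 nM. Compound 2 stands apart from both others: compound 1 sits at a higher number by a margin beyond the scatter, and compound 3 further still. No two of these compounds differ in a single place, so no step is charted between them; the three values are read as they stand.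

Compound 4 `NNC(=O)CCc1ccncc1-c1ccc2ccccc2c1` is the next compound, not yet measured in this assay. It departs from compound 2 in one place: amino in place of methyl on an amide-type nitrogen. The chain to the carbonyl, the pyridine and the naphthyl portion are unchanged.

Going by the values given here, no measured pair shows what this kind of change does, so the expectation rests only on compound 2. Since the change is small and sits at the far end of the side chain, the expected step from compound 2 to compound 4 is estimated as a 1.8-fold higher number from compound 2 to compound 4 (0.26 log units; within the scatter), a modest rise not clearly beyond the scatter. For compound 4 the estimated value is 38 nM, with a range from 12 nM to 120 nM.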

Compound 4, half-maximal inhibitory concentration: 7.7 nM
The estimate for compound 4 lay 4.9-fold (0.69 log units) above the measured number; the measured number lies below the stated range.
By their numbers in this assay, from the lowest: compound 4; then compound 2; then compound 1; then compound 3.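

In this assay, going by these compounds alone, amino in place of methyl on an amide-type nitrogen gives a 2.7-fold lower number from compound 2 to compound 4 (0.44 log units; beyond the scatter), the first single-place step in this set. It shows that this position responds to a one-atom change and that the methyl is not needed for a low number on this side chain, as the amino-bearing compound 4 sits lowest of the four values. By count, the amino brings one hydrogen-bond donor and one hydrogen-bond acceptor where the methyl brings neither, but no measurement here connects either feature to the lower number, so the step stands as an observation without an explanation.

With only methyl and amino shown on this nitrogen, it remains open whether hydrogen, hydroxyl, methoxy or dimethylamino there would give a number in the same range, and so whether the trend follows anything beyond this single pair. On these data alone, it is also open whether the same change would give a step of similar size on the core of compound 1 or with the longer chain of an ethylamino group.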